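Aryl change from compound 2 to compound 3

The compounds below may be only part of what the source reports. "The series", "measured", "known", "first", "only" and "open" are said of these compounds alone.

Measured in a functional assay on A549 cells (Homo sapiens) for antiproliferative activity, read by spectrophotometry, with a stated time of 2 days; on this read-out higher numbers stand for weaker inhibition of growth and lower numbers for stronger inhibition of growth:
- compound 1 `Cc1ccc(Nc2ncc(C(F)(F)F)c(N3Cc4cccc(N(C)S(C)(=O)=O)c4C3)n2)cc1C`: > 30000 nM, a limit of the assay and not a number
- compound 2 `COc1cc(Nc2ncc(C(F)(F)F)c(N3Cc4cccc(N(C)S(C)(=O)=O)c4C3)n2)c(OC)cc1Cl`: 7300 nM

For the measured compounds named here, compound 2 holds the only true number so far. Compound 3 `Cc1cc(Cl)ccc1Nc1ncc(C(F)(F)F)c(N2Cc3cccc(N(C)S(C)(=O)=O)c3C2)n1` carries 4-chloro-2-methylphenyl in place of 4-chloro-2,5-dimethoxyphenyl on a nitrogen on an aromatic ring. Going by the values given here, only one measured step changes this place, an at least 4.1-fold lower number from compound 1 to compound 2 (0.61 log units; beyond the scatter), and there the arrival of 4-chloro-2,5-dimethoxyphenyl lowered the number. Losing that group is therefore expected to give a modest move toward a higher number in this assay. The estimated step is a 2.1-fold higher number from compound 2 to compound 3 (0.31 log units; beyond the scatter). For compound 3 the expected value is 15000 nM, with an estimated range of 6000 nM to 30000 nM.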

Compound 3, concentration for 50% growth inhibition: 25500 nM
Compound 3: middle estimate off by 1.7-fold (0.23 log units), on the low side; measured number inside the range.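

In this assay, 4-chloro-2-methylphenyl in place of 4-chloro-2,5-dimethoxyphenyl on a nitrogen on an aromatic ring gives a 3.5-fold higher number from compound 2 to compound 3 (0.54 log units; beyond the scatter), with the 4-chloro group present on both sides of the change. The chlorine alone therefore does not hold the number of compound 2, and this position stays sensitive to the other groups on the phenyl. Compound 1 gives > 30000 nM, a limit and not a number, so its step to compound 3 can be read only as a floor: the limit of > 30000 nM in this assay, at which 1 of the 3 values shown sits.
All that can be given is an at least 1.1-fold lower number from compound 1 to compound 3 (0.07 log units; that floor lies within the scatter), which sets no order.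

Which methoxy group matters stays open, as both leave together while a methyl enters. So does the effect of an amine or a carboxylic acid on this phenyl.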